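An Aryl Exchange on the Shared Core

A few compounds are considered here, and "the series" means these few. Any claim that something is new, unique, unknown or untested is made for them only; others in the source may bear on it.

In a functional assay on NCI-H322 cells (Homo sapiens) for cytotoxicity, read by MTT assay, with a stated time of 24 h (on this read-out lower numbers stand for stronger inhibition and higher numbers for weaker inhibition), compound 1 `COc1ccc(/C=C\C(=O)O)c(OCc2cn(-c3ccc(NC(C)=O)cc3)nn2)c1CC=C(C)C` gives 45700 nM and compound 2 `COc1ccc(/C=C\C(=O)O)c(OCc2cn(-c3ccc(CO)cc3)nn2)c1CC=C(C)C` gives 27100 nM so the two cannot be told apart beyond the scatter. Compound 3 `COc1ccc(/C=C\C(=O)O)c(OCc2cn(-c3cccnc3Cl)nn2)c1CC=C(C)C` has 2-chloropyridin-3-yl in place of 4-(hydroxymethyl)phenyl on an aromatic nitrogen. Among the compounds with values here, the one measured step (a 1.7-fold lower number from compound 1 to compound 2 (0.23 log units; within the scatter)) put hydroxymethyl in place of acetamido on an aromatic carbon and stayed within the scatter, so no step beyond the scatter is expected in this assay for this exchange. The estimated change is small (a 1.1-fold higher number from compound 2 to compound 3 (0.04 log units; within the scatter)). Compound 3 is expected at 30000 nM with 12000 nM to 75000 nM as its estimated range.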

Compound 3, half-maximal inhibitory concentration: 42200 nM
The estimate for compound 3 lay 1.4-fold (0.15 log units) below the measured number; the measured number falls inside the stated range.
By their numbers in this assay, from the lowest: compounds 2, 3 and 1 (each within the scatter of the next).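

At this position on the aromatic nitrogen, a ring with a hetero atom, bearing chlorine and with no hydrogen-bond donor, stays within the scatter in this assay of both earlier aryl groups (the hydroxymethyl exchange gives a 1.6-fold higher number from compound 2 to compound 3 (0.19 log units; within the scatter); the acetamido exchange gives a 1.1-fold lower number from compound 1 to compound 3 (0.03 log units; within the scatter)). The three compounds therefore cannot be told apart, whether the entering ring is carbon-only or not. Nothing measured here explains this result.

The compounds shown leave open whether an amine or a longer alkyl chain on this aryl group would give a step beyond the scatter.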